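From Iodo to Methyl on the Aromatic Carbon

This account rests on a few compounds, and the source may have more. Where it says the series, first, only, none or still open, it means among the compounds named here.

Compound 1 `CCCCOc1ccccc1Cc1cnc(N)nc1N` carries a butoxy group and in an assay for inhibition of Dihydrofolate reductase (Gallus gallus) (on this read-out lower numbers stand for stronger inhibition and higher numbers for weaker inhibition), compound 1 gives 8710 nM. Compound 2 `Nc1ncc(Cc2ccccc2I)c(N)n1` carries an iodo group instead, and in this assay compound 2 gives 8710 nM. The step of no change at the digits printed from compound 1 to compound 2 (within the scatter) shows that exchanging one group on that aromatic carbon left the inhibition constant unchanged. Compound 2 therefore stands level with compound 1 within the scatter.

Compound 3 `Cc1ccccc1Cc1cnc(N)nc1N` differs from compound 2 by methyl in place of iodo on an aromatic carbon. For the measured compounds named here, the only measured step that bears on this is no change at the digits printed from compound 1 to compound 2 (within the scatter), which was flat, so a further exchange at the same aromatic carbon is expected to produce no step beyond the scatter in this assay. The step from compound 2 to compound 3 is expected to be a 1.0-fold higher number from compound 2 to compound 3 (0.01 log units; within the scatter). Compound 3 is accordingly estimated at 9000 nM, with a range from 3000 nM to 27000 nM.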

Compound 3, inhibition constant: 29500 nM
Compound 3: the middle estimate sits 3.3-fold (0.52 log units) below what was measured, outside the stated range (above it).
By their numbers in this assay, from the lowest: compounds 1 and 2 (each within the scatter of the next); then compound 3.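

The exchanges at this aromatic carbon are not all flat: the level result for butoxy and iodo does not extend to methyl. In this assay the change to methyl gives a 3.4-fold higher number from compound 2 to compound 3 (0.53 log units; beyond the scatter) and, against butoxy, a 3.4-fold higher number from compound 1 to compound 3 (0.53 log units; beyond the scatter) in the same direction. Iodo and methyl have the same heavy-atom count, so that count alone does not sort these three compounds. Nothing available here explains the step.

From the compounds shown here alone, what an amine or a carboxylic acid would do on this aromatic carbon remains open. So does whether a chain longer than butoxy would stay level with compound 1 or move away from it.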